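The compounds below may be only part of what the source reports. "The series", "measured", "known", "first", "only" and "open" are said of these compounds alone.

The shared core appears in compound 1 `CCCCCCCN1CCC(C(=O)Nc2cc(Cl)c(N)cc2OC)CC1`. In a functional assay on the whole organism for antagonist activity, with Mus musculus as the target (on this read-out lower numbers stand for an effect already at smaller amounts and higher numbers for an effect only at larger amounts of compound), compound 1 gives only a limit, > 10 mg/kg, so its true number is not known. Among the three measured compounds, compound 1 sits at one of two limits, the limit of > 10 mg/kg in this assay, at which 1 of the 3 values shown sits, being its own. Compound 2 `COc1cc(N)c(Cl)cc1NC(=O)C1CCN(Cc2cccc(C#N)c2)CC1` also gives only a limit in this assay, > 4 mg/kg. Compound 3 `COc1cc(N)c(Cl)cc1NC(=O)C1CCN(Cc2cccc(C)c2)CC1` gives a number in this assay, 2.4 mg/kg. Compound 4 `COc1cc(N)c(Cl)cc1NC(=O)C1CCN(C2CCCC2)CC1` differs from compound 1 in one place: cyclopentyl in place of heptyl on an amine nitrogen in a ring. The measured step that comes closest is an at least 4.1-fold lower number from compound 1 to compound 3 (0.61 log units; beyond the scatter), where the long chain on the ring nitrogen was also replaced, though there an aromatic group entered. The step that the two limits leave unreadable from compound 1 to compound 2 gives no readable size. Among the measured compounds shown here, no measured step swaps the chain for a saturated ring, and the starting point for compound 1 is only a limit, so the size of the step to compound 4 cannot be read from the data. The estimated step is therefore an at least 1.2-fold lower number from compound 1 to compound 4 (0.09 log units; that floor lies within the scatter), small and uncertain. Compound 4 is expected to give about 8 mg/kg in this assay, within 2 mg/kg to 30 mg/kg, and a limit rather than a number is a real possibility.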

Compound 4, dose for half-maximal effect: > 10 mg/kg
Compound 4 was reported as a limit; the forecaster's own chance of this, stated with the estimate: 50%; at least 1.2-fold (0.09 log units) between middle value and limit.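

Replacing 3-methylbenzyl with cyclopentyl on the amine nitrogen in a ring gives, in this assay, an at least 4.1-fold higher number from compound 3 to compound 4 (0.61 log units; beyond the scatter), so this saturated ring does not keep the result seen with the 3-methylbenzyl group of compound 3. Compound 4 gives only a limit, the same limit as compound 1: the limit of > 10 mg/kg in this assay, at which 2 of the 4 values shown sit. The steps from compound 1 and from compound 2 to compound 4 cannot be read, as both ends of each step are limits, so neither heptyl nor 3-cyanobenzyl can be ranked against cyclopentyl.

With compound 3 the only one of the four giving a number, the compounds shown leave open how much the dose would change for any other group on this nitrogen, and whether the true values of compound 1 and compound 4 differ at all. Plain benzyl, with no group on its aromatic ring, would help separate the part played by the aromatic ring from that of the methyl, while cyclohexyl would test whether a larger saturated ring behaves like cyclopentyl.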